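A few compounds are considered here, and "the series" means these few. Any claim that something is new, unique, unknown or untested is made for them only; others in the source may bear on it.

Measured so far:
- compound 1, `O=C1CCCC2=C1C(c1ccc(F)cc1)C=C(c1ccccc1)N2`: 21.9%
- compound 2, `CCOC(=O)C1(O)CC(c2ccc(Cl)cc2)C2=C(CC(C)(C)CC2=O)O1`: "not active" (no number reported)

Two compounds have a result in an assay on isolated protein for inhibition of glucose-6-phosphatase catalytic subunit 1 (Homo sapiens), read by inositol phosphate accumulation, with a stated time of 30 min, tested at 100 uM; a higher number here means more inhibition at the concentration tested (going by the name of the read-out), a lower number less inhibition. Compound 1 gives 21.9% in this assay, and compound 2 is reported in this assay as "not active" (no number reported), without a number. Compound 1 thus stands on the only number shown; the single further entry carries no figure to set beside it. Compound 2 shares no single-point difference with compound 1, so its entry says nothing about the step that follows.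

The next compound, compound 3 `O=C1CCCC2=C1C(c1ccc(Cl)cc1)C=C(c1ccccc1)N2`, differs from compound 1 in one place: chloro in place of fluoro on an aromatic carbon. Going by the values given here, no step between measured compounds is available to anchor the size of this change, so the expectation rests on the structural change alone, a chloro in place of a fluoro on an aromatic carbon. For such a swap, the step is expected to be small, not beyond the usual scatter of this assay, with at most a slight lean toward more inhibition. The step from compound 1 to compound 3 is therefore estimated at a number 3.1 percentage points higher from compound 1 to compound 3 (within the scatter) in this assay. Compound 3 is accordingly expected to give about 25%, with a range from 10% to 40%.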

Compound 3, a percentage reported as inhibition, at one concentration (the size of the read-out at that concentration, not a potency): 8.21%
Compound 3: the middle estimate sits 16.8 percentage points above what was measured, outside the stated range (below it).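

In this assay, going by these compounds alone, the exchange of 4-fluorophenyl for 4-chlorophenyl gives the first step that can be read at this place on the shared core, and the result is a number 13.7 percentage points lower from compound 1 to compound 3 (beyond the scatter). The place, on an aromatic carbon para to a large group, is therefore not indifferent to which halogen it carries, even though the fluoro and the chloro match in heavy atom count, in hydrogen-bond donors and acceptors, and in net charge. No measurement shown accounts for this difference between compound 1 and compound 3.

This remains a single step between two compounds, each read at one concentration, so it gives no trend across substituents and no measure of potency. The compounds shown leave open how a bromo, a methoxy, a nitrile or a carboxylic acid at the same place would read, and whether the phenyl group elsewhere on the core responds to such a swap in the same way.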